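Aryl piperazine series: fluoro to chloro on the phenyl

The source may hold more compounds than are shown below. What is called first, only, known or untested is meant among the compounds shown, and "the series" means these compounds.

Measured so far:
compound 1 `Nc1scc(CN2CCN(c3ccc(Cl)cc3Cl)CC2)c1C(=O)c1ccc(Cl)cc1` — 0%
compound 2 `Nc1scc(CN2CCN(c3ccc(Cl)c(C(F)(F)F)c3)CC2)c1C(=O)c1ccc(Cl)cc1` — 3%
compound 3 `Nc1scc(CN2CCN(c3cccc(F)c3)CC2)c1C(=O)c1ccc(Cl)cc1` — 4%

All three share one core and differ only in the aryl group on the amine nitrogen in the ring. In an assay on CHO cells for displacement of a labelled ligand from adenosine receptor A3 (Homo sapiens), read by scintillation counting, with a stated time of 120 min, tested at 10 uM (a lower number here means less inhibition, a higher number more inhibition at the concentration tested (going by the name of the read-out)), compound 3 gives 4%, numerically the largest of the three numbers, but the gaps to the others are within the scatter: a number 1 percentage points higher from compound 2 to compound 3 (within the scatter) and a number 4 percentage points higher from compound 1 to compound 3 (within the scatter). The third step, a number 3 percentage points higher from compound 1 to compound 2 (within the scatter), is likewise within the scatter. Every aryl exchange tried so far, whether a whole pattern of halogens or a single fluoro, has left this assay flat near zero.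

Compound 4 `Nc1scc(CN2CCN(c3cccc(Cl)c3)CC2)c1C(=O)c1ccc(Cl)cc1` is the next point; it differs from compound 3 by chloro in place of fluoro on an aromatic carbon. This is the smallest change in the set, a single halogen for another on the same aromatic carbon, and the larger aryl exchanges above each bear on it only by showing no movement beyond the scatter. Among the compounds with values here, no step in this assay, therefore, is expected from compound 3 to compound 4: no change at the digits printed from compound 3 to compound 4 (within the scatter). Compound 4 is expected to read 4%, in the range 0% to 12%.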

Compound 4, a percentage reported as inhibition, at one concentration (the size of the read-out at that concentration, not a potency): 1%
For compound 4 the middle estimate is 3 percentage points above the measured one; the measured number falls inside the stated range.
By their numbers in this assay, from the lowest: compounds 1, 4, 2 and 3 (each within the scatter of the next).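

In this assay, within the data shown here, the only single-halogen exchange in the set, on an aromatic carbon meta to a large group, gives a number 3 percentage points lower from compound 3 to compound 4 (within the scatter) and so does not separate chloro from fluoro at this position. The 3-chlorophenyl group also cannot be told apart from the two more heavily substituted aryl groups, with a number 2 percentage points lower from compound 2 to compound 4 (within the scatter) and a number 1 percentage points higher from compound 1 to compound 4 (within the scatter), so the bare halogen swap and the larger aryl exchanges give the same picture: all four compounds lie within the scatter of one another near zero. No measurement shown bears on this result, so the flat reading stays a description and nothing more.

Still open, going by these compounds, is whether a group of another kind in the same place, such as a carboxylic acid, a primary amine or a nitrile, would lift the reading in this assay clear of the scatter. Also open, on these data alone, is whether the flat reading belongs to the aryl group at all or would hold when the amino group or the 4-chlorophenyl ketone of the shared core is replaced, for example by an amide or a longer chain.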